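This account rests on a few compounds, and the source may have more. Where it says the series, first, only, none or still open, it means among the compounds named here.

Three hydrazones built on one shared core have been measured in a functional assay (Mus musculus, strain BALB/C) for inhibition, read by MTT assay, with stated times of 24 h and 72 h; a higher number here means a weaker inhibitor, a lower number a stronger inhibitor. Compound 1 `Cc1ccc(C(=O)N/N=C/c2ccccc2F)c(O)c1` gives 42100 nM, compound 2 `Cc1ccc(C(=O)N/N=C/c2ccccc2)c(O)c1` gives 53900 nM, and compound 3 `Cc1ccc(C(=O)N/N=C/c2ccccc2O)c(O)c1` gives 1020 nM, the lowest of the three numbers and beyond the scatter from both others. The step of a 1.3-fold higher number from compound 1 to compound 2 (0.11 log units; within the scatter) is small, whereas a 41-fold lower number from compound 1 to compound 3 (1.62 log units; beyond the scatter) and a 53-fold lower number from compound 2 to compound 3 (1.72 log units; beyond the scatter) are large, and in each of these the entering group was the hydroxy. Compound 4 `Cc1ccc(C(=O)N/N=C/c2ccccc2[N+](=O)[O-])c(O)c1` is not yet measured; it differs from compound 3 by nitro in place of hydroxy on an aromatic carbon. Nitro has no precedent among these compounds, and the hydroxy that now leaves carried both large lowerings, so a large rise toward the numbers of the first two compounds is expected for compound 4, a 29-fold higher number from compound 3 to compound 4 (1.47 log units; beyond the scatter). The estimate for compound 4 in this assay is 30000 nM, within 8000 nM to 90000 nM.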

Compound 4, half-maximal inhibitory concentration: > 100000 nM
Compound 4: no number, only a limit; the forecaster's own chance of this, stated with the estimate: 10%; at least 3.3-fold (0.52 log units) between middle value and limit.
By their numbers in this assay, from the lowest: compound 3; then compounds 1 and 2 (each within the scatter of the next). At a limit, above all of these: compound 4.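

In this assay compound 4 sits at a limit of the assay, not at a number: the limit of > 100000 nM in this assay, at which 1 of the 4 values shown sits. Nitro in place of hydroxy removes the whole lowering seen at this position, with an at least 98-fold higher number from compound 3 to compound 4 (1.99 log units; beyond the scatter), and nitro in place of fluoro also separates, with an at least 2.3-fold higher number from compound 1 to compound 4 (0.37 log units; beyond the scatter), while nitro in place of hydrogen stays unresolved, with an at least 1.8-fold higher number from compound 2 to compound 4 (0.26 log units; that floor lies within the scatter). Among the four groups shown here, only the hydroxy gives a low number. Going by these compounds, whether an amine or a methoxy group at this position would also give one stays open, as does the true value of compound 4 behind its limit.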